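The compounds below may be only part of what the source reports. "The series", "measured", "known", "first", "only" and "open" are said of these compounds alone.

Going by the values given here, compound 3 `Cn1c(=O)c(=O)n(C2CCCC2)c2nc(N/N=C/c3ccc(C(F)(F)F)cc3)ncc21` gives 23600 nM in a functional assay on PC-3 cells (Homo sapiens) for antiproliferative activity, read by MTT assay (on this read-out higher numbers stand for weaker inhibition and lower numbers for stronger inhibition), the highest of the three numbers measured so far. Its nearest neighbour is compound 2 `COc1cccc(/C=N/Nc2ncc3c(n2)n(C2CCCC2)c(=O)c(=O)n3C)c1`, which gives 20700 nM, a gap that lies within the scatter; furthest from it is compound 1 `Cn1c(=O)c(=O)n(C2CCCC2)c2nc(N/N=C/c3ccc(F)c(Cl)c3)ncc21`, which gives 8550 nM, a gap that lies beyond it. Compound 4 `Cc1cc(C)c(/C=N/Nc2ncc3c(n2)n(C2CCCC2)c(=O)c(=O)n3C)c(C)c1` differs from compound 3 by 2,4,6-trimethylphenyl in place of 4-(trifluoromethyl)phenyl on a carbon with a double bond to nitrogen. Two of the measured steps bear on such a swap of the aryl group on a carbon with a double bond to nitrogen: a 2.8-fold higher number from compound 1 to compound 3 (0.44 log units; beyond the scatter) and a 1.1-fold higher number from compound 2 to compound 3 (0.06 log units; within the scatter). Both are modest or within the scatter, so the measured aryl swaps have moved this read-out only a little. Compound 4 is therefore expected to sit close to compound 3, with a step of a 1.1-fold lower number from compound 3 to compound 4 (0.03 log units; within the scatter) that need not exceed the scatter in either direction. Compound 4 is estimated at 22000 nM, with a range from 7000 nM to 65000 nM.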

Compound 4, half-maximal inhibitory concentration: 13900 nM
Compound 4: the middle estimate sits 1.6-fold (0.20 log units) above what was measured; low and high end bracket the measured number.
By their numbers in this assay, from the lowest: compounds 1, 4, 2 and 3 (each within the scatter of the next, the first and the last beyond it).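

In this assay, placing 2,4,6-trimethylphenyl on a carbon with a double bond to nitrogen gives a 1.7-fold lower number from compound 3 to compound 4 (0.23 log units; within the scatter) and a 1.5-fold lower number from compound 2 to compound 4 (0.17 log units; within the scatter) and also a 1.6-fold higher number from compound 1 to compound 4 (0.21 log units; within the scatter). Compound 4 therefore lies within the scatter of all three earlier compounds, even though compound 1 and compound 3 are separated beyond it, so an aryl group made only of carbon, with no fluorine, chlorine or oxygen, stays in the range already seen at this position. Nothing shown here explains this result.

As far as these compounds go, all four groups at this position are carbon-only aromatic rings with neutral or uncharged substituents, so it remains open whether a pyridine ring, or an amine or carboxylic acid on the phenyl ring, would change the number beyond the scatter. From the compounds shown here alone, the rest of the molecule is the same in all four compounds, so the effect of changes elsewhere also remains open.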